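Triazolylmethyl series: benzyl for fluorophenyl on the triazole

This account rests on a few compounds, and the source may have more. Where it says the series, first, only, none or still open, it means among the compounds named here.

Working notes on three measured compounds and one still open. Compound 1 `CCCCCc1ccc(C#Cc2c(-c3ccc(CCCCC)cc3)oc3nc(=O)n(Cc4cn(-c5ccccc5F)nn4)cc23)cc1`, compound 2 `O=c1c(I)cn(Cc2cn(Cc3ccccc3)nn2)c(=O)n1Cc1cn(Cc2ccccc2)nn1` and compound 3 `CCCCCCC#Cc1c(CCCCCC)oc2nc(=O)n(Cc3cn(Cc4ccccc4)nn3)cc12` were all run in a functional assay on A549 cells (Homo sapiens) for antiproliferative activity, read by MTT assay, with a stated time of 72 h; on this read-out lower numbers stand for stronger inhibition and higher numbers for weaker inhibition. Compound 1 gives 38700 nM, compound 2 gives 41300 nM and compound 3 gives 21900 nM. Compound 1 has the second highest of the three numbers; its gap to compound 2 and its gap to compound 3 both stay within the scatter, so the three compounds cannot be told apart on this read-out and none of them can be called the most or least active.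

Compound 4 `CCCCCc1ccc(C#Cc2c(-c3ccc(CCCCC)cc3)oc3nc(=O)n(Cc4cn(Cc5ccccc5)nn4)cc23)cc1` has not been measured. It differs from compound 1 in one place: benzyl in place of 2-fluorophenyl on an aromatic nitrogen. Among the measured compounds shown here, no measured pair carries this change on its own, so its size is not known here. Compound 2 and compound 3 already carry a benzyl group on a triazole nitrogen and give numbers in the same range as compound 1; on that basis no step beyond the scatter is expected in either direction.

For compound 4 in this assay the expected value is 36000 nM, with a range from 15000 nM to 85000 nM. This estimate means a step from compound 1 to compound 4 of a 1.1-fold lower number from compound 1 to compound 4 (0.03 log units; within the scatter), which is expected to lie within the scatter.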

Compound 4, half-maximal inhibitory concentration: > 100000 nM
Compound 4: a limit, no number (the forecaster's own chance of this, stated with the estimate: 15%); middle value at least 2.7-fold (0.44 log units) away from the limit.
By their numbers in this assay, from the lowest: compounds 3, 1 and 2 (each within the scatter of the next). At a limit, above all of these: compound 4.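

Among the compounds shown here, the change from 2-fluorophenyl to benzyl on the aromatic nitrogen gives an at least 2.5-fold higher number from compound 1 to compound 4 (0.41 log units; beyond the scatter) in this assay, and this is the first step that can be read. Compound 4 gives > 100000 nM, which is a limit of the assay and not a number, so the step is bounded on one side only: the limit of > 100000 nM in this assay, at which 1 of the 4 values shown sits. Compound 2 and compound 3 also carry benzyl on a triazole nitrogen, but each differs from compound 4 in more than one place, so neither could show what this change does on the core of compound 1, where the two groups turn out not to be interchangeable.

The compounds shown leave open whether the step follows from the loss of the fluorine or from the added carbon of benzyl; plain phenyl and 2-fluorobenzyl on the same nitrogen would separate the two. Also open is whether the change acts alike on the core of compound 3, whose 2-fluorophenyl partner is not among the compounds shown.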